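The compounds below may be only part of what the source reports. "The series", "measured", "known", "first", "only" and "open" are said of these compounds alone.

Compound 1 `O=C1C(Nc2ccccc2F)=CC(=O)c2c1nc1n2[C@H]2OC[C@@H](O)[C@H]2OC1` shares its core with compound 2 `CCc1ccc(NC2=CC(=O)c3nc4n(c3C2=O)[C@H]2OC[C@@H](O)[C@H]2OC4)cc1` and compound 3 `Cc1ccc(NC2=CC(=O)c3nc4n(c3C2=O)[C@H]2OC[C@@H](O)[C@H]2OC4)cc1`, which differ from it only in the group on the amine nitrogen. In a functional assay on MCF7 cells (Homo sapiens) for inhibition, read by sulforhodamine B assay (a lower number here means a stronger inhibitor, a higher number a weaker inhibitor), compound 1 gives > 4000 nM, which is a limit of the assay rather than a number, as noted in the limit of > 4000 nM in this assay, at which 1 of the 3 values shown sits. Compound 2 gives 960 nM in this assay. Compound 3 gives 1660 nM in this assay, and the step of a 1.7-fold higher number from compound 2 to compound 3 (0.24 log units; within the scatter) lies within the scatter. Compound 1 therefore stands at the limit, with the two numbered compounds sitting well inside the measurable range. Compound 4 `O=C1C(NCc2ccccc2)=CC(=O)c2c1nc1n2[C@H]2OC[C@@H](O)[C@H]2OC1` is not yet measured; it differs from compound 1 as follows: benzyl in place of 2-fluorophenyl on an amine nitrogen. Among the measured compounds shown here, no measured step touches the group on the amine nitrogen in this way, since the one step known, from an ethyl to a methyl, concerns a saturated chain carbon bound to an aromatic carbon and falls within the scatter. The change from (2-fluorophenyl)amino to benzylamino is therefore untested here, and the starting point is only a limit, so the direction of the step of an at least 1.3-fold lower number from compound 1 to compound 4 (0.12 log units; that floor lies within the scatter) is an expectation without a measured anchor. Compound 4 is expected to give 3000 nM in this assay, with a range from 900 nM to 10000 nM.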

Compound 4, half-maximal inhibitory concentration: > 8000 nM
Compound 4 ended at the assay's limit; the forecaster's own chance of this, stated with the estimate: 40%; at least 2.6-fold (0.42 log units) between middle value and limit.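

Compound 1 and compound 4 both stand at limits of the assay rather than at numbers, and the step between them cannot be read. The compounds shown leave open whether benzyl in place of 2-fluorophenyl on an amine nitrogen changes the result in this assay at all, and in which direction.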